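Shortening a Side Chain on a Nucleoside Analogue

The source may report more compounds than this note shows. Statements on the series, on what has been measured and on what is new or still open speak of the compounds shown alone.

Compound 1 `CCCCCc1ccc(CCc2cc3cn([C@H]4C[C@H](O)[C@@H](CO)O4)c(=O)nc3o2)cc1` was tested in an ADME assay on HEL cells (Homo sapiens) for cytotoxicity, with a stated time of 3 days; on this read-out lower numbers stand for higher toxicity in this test and higher numbers for lower toxicity in this test. In this assay compound 1 gives >= 470000 nM, which is a limit of the assay rather than a measured number. Compound 1 therefore sits at the limit of >= 470000 nM in this assay, at which 1 of the 2 values shown sits. Among the measured compounds shown here, only one other compound is available in this assay. Compound 2 `CCCCCc1cnc(-c2cc3cn([C@H]4C[C@H](O)[C@@H](CO)O4)c(=O)nc3o2)nc1` differs from compound 1 in another part of the structure. In this assay compound 2 gives > 100000 nM, again a limit of the assay and not a number. Compound 2 sits at the limit of > 100000 nM in this assay, at which 1 of the 2 values shown sits. With both values limits, the two compounds show only that no toxicity appeared within the reach of the test.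

Compound 3 `CCCc1ccc(CCc2cc3cn([C@H]4C[C@H](O)[C@@H](CO)O4)c(=O)nc3o2)cc1` has not yet been measured. It differs from compound 1 by hydrogen in place of ethyl on a saturated chain carbon, three bonds along the chain from an aromatic carbon. For the measured compounds named here, no pair of measured compounds shows the effect of this change. Because compound 1 gives >= 470000 nM, a limit, the expected step of an at least 1.1-fold lower number from compound 1 to compound 3 (0.07 log units; that floor lies within the scatter) is none beyond the scatter, with the result most likely to be a limit once more. Compound 3 is accordingly expected to give 400000 nM, within 100000 nM to 1000000 nM.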

Compound 3, minimum cytotoxic concentration: >= 130000 nM
Compound 3: a limit, no number; the forecaster's own chance of this, stated with the estimate: 85%; the middle value does not contradict the limit.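

In this assay compound 3 gives >= 130000 nM, which is a limit of the assay and not a number. Compound 1 also stands at a limit, and the step between compound 1 and compound 3 cannot be read. The compounds shown leave open whether going from pentyl to propyl changes toxicity in these cells at all.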